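A few compounds are considered here, and "the series" means these few. Any claim that something is new, unique, unknown or untested is made for them only; others in the source may bear on it.

Compound 2 `Cc1cc(C(=O)NC2CC2)nn1Cc1cc(Cl)cc2cc(-c3ccccc3)oc12` stands as the stronger of the two measured compounds: in an assay on CHO-K1 cells for displacement of a labelled ligand from prostaglandin E2 receptor EP1 subtype (Homo sapiens), read by scintillation counting, with a stated time of 45 min (a higher number here means a weaker inhibitor, a lower number a stronger inhibitor), compound 2 gives 5.01 nM, while compound 1 `CO[C@H]1CC[C@H](NC(=O)c2cc(C)n(Cc3cc(Cl)cc4cc(C(C)C)oc34)n2)CC1` gives 316 nM, a gap well beyond the scatter. Compound 3 `Cc1cc(C(=O)NC[C@H]2CCCO2)nn1Cc1cc(Cl)cc2cc(-c3ccccc3)oc12` has not yet been measured. It differs from compound 2 at a single site: (oxolan-2-yl)methyl in place of cyclopropyl on an amide-type nitrogen. For the measured compounds named here, no pair of measured compounds isolates this change, so any expectation rests on compound 2 alone. Compound 3 is expected to weaken modestly, a 3.0-fold higher number from compound 2 to compound 3 (0.48 log units; beyond the scatter) in this assay. Compound 3 is therefore estimated at 15 nM, with a range from 4 nM to 60 nM.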

Compound 3, half-maximal inhibitory concentration: 6.31 nM
Compound 3: the middle estimate sits 2.4-fold (0.38 log units) above what was measured, and the stated range covers the measured number.
By their numbers in this assay, from the lowest: compounds 2 and 3 (each within the scatter of the next); then compound 1.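

In this assay, for the compounds shown here, the step reads a 1.3-fold higher number from compound 2 to compound 3 (0.10 log units; within the scatter), so on this amide-type nitrogen the two groups cannot be told apart, a reading no earlier pair of compounds could give. The site thus holds (oxolan-2-yl)methyl, with its 6 heavy atoms, one hydrogen-bond acceptor and defined stereocentre, as well as it holds cyclopropyl. No evidence here accounts for this result. Going by these compounds, it remains open whether the opposite stereoisomer of (oxolan-2-yl)methyl would read the same. Also open, on these data alone, is how an amine or carboxylic acid on a longer chain would fare at this nitrogen.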